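The compounds below may be only part of what the source reports. "The series", "measured", "known", "first", "only" and "open" are said of these compounds alone.

Measured compounds in this set:

- compound 1, `Nc1cc(-c2cnc3[nH]cc(-c4ccncc4)c3c2)ccc1Cl`: 53.7 nM in an assay on isolated protein for inhibition of high affinity nerve growth factor receptor (Homo sapiens), read by 33P incorporation; a higher number here means a weaker inhibitor, a lower number a stronger inhibitor
- compound 2, `Nc1cccc(-c2cnc3[nH]cc(-c4ccncc4)c3c2)c1`: 42.7 nM
- compound 3, `COc1ccc(N)cc1-c1cnc2[nH]cc(-c3ccncc3)c2c1`: 110 nM

Compound 2 gives the lowest number of the three, but the step is only a 1.3-fold lower number from compound 1 to compound 2 (0.10 log units; within the scatter), which is within the scatter, so the two are not separable; only compound 3 stands apart, at a 2.6-fold higher number from compound 2 to compound 3 (0.41 log units; beyond the scatter).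

Compound 4, `COc1cccc(-c2cnc3[nH]cc(-c4ccncc4)c3c2)c1`, is not yet measured. Relative to compound 2 the change is methoxy in place of amino on an aromatic carbon, on an aromatic carbon of a six-membered aromatic ring of carbon only, meta to a large group.

Going by the values given here, no measured step swaps amino for methoxy directly. The nearest bearing is the step from compound 2 to compound 3, where a methoxy entering on the same ring cost a 2.6-fold higher number from compound 2 to compound 3 (0.41 log units; beyond the scatter), a modest loss. Removing the amino (a hydrogen-bond donor) and putting methoxy in its place is expected to be at least as costly, so a modest rise in this assay is expected, a 2.6-fold higher number from compound 2 to compound 4 (0.41 log units; beyond the scatter).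

Compound 4 is therefore estimated at 110 nM, with a range of 40 nM to 320 nM.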

Compound 4, half-maximal inhibitory concentration: 22.7 nM
Compound 4: middle estimate off by 4.8-fold (0.69 log units), on the high side, outside the stated range (below it).
By their numbers in this assay, from the lowest: compounds 4, 2 and 1 (each within the scatter of the next, the first and the last beyond it); then compound 3.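

At this carbon, meta to a large group, amino can give way to methoxy with a 1.9-fold lower number from compound 2 to compound 4 (0.27 log units; within the scatter) in this assay, so a hydrogen-bond donor on the amino group is not needed here to keep the number in the range of compound 2. The cost seen with a 2.6-fold higher number from compound 2 to compound 3 (0.41 log units; beyond the scatter), where methoxy joins the amino group at another carbon of the ring, therefore does not extend to methoxy on this ring in general. Nothing available here bears on why the two methoxy changes differ.

As far as these compounds go, whether a larger ether such as ethoxy, or a hydroxy group, would fit this carbon as well as methoxy stays open. So does the effect of methoxy on compound 1, whose chloro group could alter how this carbon tolerates the change.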